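The source may report more compounds than this note shows. Statements on the series, on what has been measured and on what is new or still open speak of the compounds shown alone.

Of the compounds shown here, two of one shared core have been measured in a physicochemical assay for lipophilicity; a lower number here means a more polar compound, a higher number a more lipophilic compound. Compound 1, `Cc1cc(Cl)c(-c2cn(C)cn2)cc1NC(=O)c1ccc(OCc2ccccn2)cc1`, gives 3.1. Compound 2, `Cc1cc(C)c(-c2ncc[nH]2)cc1NC(=O)c1ccc(OCc2ccccn2)cc1`, gives 3.1. On these numbers compound 2 stands level with compound 1 at the digits shown, and the two values lie within the scatter of each other, so nothing separates them.

The next compound, compound 3, `Cc1cc(C)c(-c2cn(C)cn2)cc1NC(=O)c1ccc(OCc2ccccn2)cc1`, is not yet measured. It differs from compound 2 in one place: 1-methyl-1H-imidazol-4-yl in place of 1H-imidazol-2-yl on an aromatic carbon. The amide, the ether-linked benzyl-type arm with its pyridine, and the two methyl groups on the central ring stay the same.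

Among the compounds with values here, no measured pair here shows exactly this exchange, so its effect can only be estimated. Compound 1 carries the same 1-methyl-1H-imidazol-4-yl group and gives 3.1. Against that background the step from compound 2 to compound 3 is expected to be small, a number 0.10 log units higher from compound 2 to compound 3 (within the scatter), at most a slight rise that may stay within the scatter. Compound 3 is therefore estimated at 3.2 in this assay, with a range from 2.7 to 3.7.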

Compound 3, distribution coefficient: 3
Compound 3: middle estimate off by 0.20 log units, on the high side, within the range that was stated.
By their numbers in this assay, from the lowest: compounds 3, 1 and 2 (each within the scatter of the next).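

In this assay, placing 1-methyl-1H-imidazol-4-yl instead of 1H-imidazol-2-yl on the aromatic carbon that is ortho to one methyl group and para to another gives a number 0.10 log units lower from compound 2 to compound 3 (within the scatter) and so leaves the two compounds indistinguishable, even though the two groups differ in their counts of hydrogen-bond donors and acceptors. The second exchange, methyl in place of chloro on an aromatic carbon, gives a number 0.10 log units lower from compound 1 to compound 3 (within the scatter) and likewise leaves its two compounds indistinguishable, so for these three compounds neither change separates the readings in this assay. Nothing available here explains why these readings stay together, and the size of the steps is all that can be said.

Still open, from the compounds shown here alone, is whether a quite different group on the carbon that carries the imidazole, such as a carboxylic acid or a primary amine, would give a step beyond the scatter. The same question stands for the place that holds chloro in compound 1 and methyl in compound 3, where a methoxy group or a nitrile could be compared with these two.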